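Ether Substituent Size and Tolerated Concentration in HEL Cells

The source may hold more compounds than are shown below. What is called first, only, known or untested is meant among the compounds shown, and "the series" means these compounds.

Compound 1 `CCC1(Cc2ccccc2)OS(=O)(=O)C=C1OC` is the parent of this series. In an ADME assay on HEL cells (Homo sapiens) for cytotoxicity, with a stated time of 3 days (a higher number here means that more compound is tolerated, a lower number that less compound is tolerated), compound 1 gives > 400000 nM, which is a limit of the assay rather than a number, (the limit of > 400000 nM in this assay, at which 1 of the 3 values shown sits). Compound 2 `C=CCOC1=CS(=O)(=O)OC1(CC)Cc1ccccc1` gives 80000 nM in this assay. Compound 3 `CCC1(Cc2ccccc2)OS(=O)(=O)C=C1OCCCCCCc1ccccc1` gives >= 20000 nM in this assay, again a limit of the assay, (the limit of >= 20000 nM in this assay, at which 1 of the 3 values shown sits). Compound 4 `CCC1(Cc2ccccc2)OS(=O)(=O)C=C1OCc1ccc(C)cc1` carries the change (4-methylphenyl in place of hydrogen on a saturated chain carbon bound to an oxygen on an unsaturated carbon). Among the compounds with values here, the only measured step at the same place, an at least 5.0-fold lower number from compound 1 to compound 2 (0.69 log units; beyond the scatter), runs toward a lower tolerated concentration when the hydrogen is replaced. With 4-methylphenyl entering instead of vinyl, the step is expected to be at least as large, estimated at an at least 6.6-fold lower number from compound 1 to compound 4 (0.82 log units; beyond the scatter). Compound 4 is therefore expected to give about 60000 nM, within a range of 15000 nM to 250000 nM.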

Compound 4, minimum cytotoxic concentration: >= 16000 nM
Compound 4 ended at the assay's limit; the forecaster's own chance of this, stated with the estimate: 30%; the middle value is on the limit's open side.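

Compound 4 sits at a limit of the assay, and its steps from compound 1 and from compound 2 cannot be read. Left open is how far 4-methylphenyl in place of hydrogen or vinyl shifts the number in this assay.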